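This account rests on a few compounds, and the source may have more. Where it says the series, first, only, none or still open, it means among the compounds named here.

Of the compounds shown here, two sharing one core have been measured so far in a physicochemical assay for solubility, read by spectrophotometry, in phosphate buffer, with a stated time of 18 h, at pH 7.4; on this read-out lower numbers stand for lower solubility and higher numbers for higher solubility. Compound 1 (`CCc1ccc(-c2nc3c(c(C)nn3-c3ccccc3)c(-c3ccccc3C(F)(F)F)c2C#N)cc1`) gives 11000 nM, and compound 2 (`CCCc1ccc(-c2nc3c(c(C)nn3-c3ccccc3)c(-c3ccccc3O)c2C#N)cc1`) gives 6500 nM. These two numbers lie within the usual scatter of repeated measurements, so neither can be ranked above the other, although the two structures differ in more than one place.

The next structure, compound 3 (`Cc1nn(-c2ccccc2)c2nc(-c3ccc([N+](=O)[O-])cc3)c(C#N)c(-c3ccccc3O)c12`), matches compound 2 except for one group: nitro in place of propyl on an aromatic carbon, para to a large group, so 4-propylphenyl becomes 4-nitrophenyl (nitro in place of propyl on an aromatic carbon). Going by the values given here, no measured pair shows what this exchange does. The only starting point is therefore the value of compound 2 itself, 6500 nM. On these data alone, with so little evidence, no step beyond the scatter is expected in this assay, and the direction remains open. The estimated change is small, a 1.1-fold higher number from compound 2 to compound 3 (0.03 log units; within the scatter). For compound 3 the expected value is 7000 nM, with an estimated range from 2500 nM to 20000 nM.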

Compound 3, solubility: 6000 nM
Beside the measured number, compound 3's estimate is 1.2-fold (0.07 log units) above it, and the stated range covers the measured number.
By their numbers in this assay, from the lowest: compounds 3, 2 and 1 (each within the scatter of the next).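

In this assay, replacing propyl with nitro on an aromatic carbon, para to a large group, gives a 1.1-fold lower number from compound 2 to compound 3 (0.03 log units; within the scatter). Going by these compounds alone, this is the first comparison here in which only one place changes. The structures of compound 1 and compound 2 differ in more than one place. This step shows that these two groups, with the same count of heavy atoms but different atoms and with hydrogen-bond acceptors only on nitro, can be exchanged here without a step beyond the scatter. No measured evidence on either group bears on this result.

This single pair leaves open whether an amine, a carboxylic acid or a longer chain at the same position would also stay within the scatter, or would produce a clear step in either direction. It also leaves open whether nitro in place of propyl would give a similar step on a compound carrying trifluoromethyl, as compound 1 does, instead of the hydroxyl group shared by compound 2 and compound 3.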